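Piperidine for morpholine: a repeated change on a methylated core

The compounds below may be only part of what the source reports. "The series", "measured", "known", "first", "only" and "open" are said of these compounds alone.

Three thiosemicarbazide-type compounds were tested in a functional assay on MCF7 cells (Homo sapiens) for cytotoxicity, read by MTT assay, with a stated time of 72 h; on this read-out higher numbers stand for weaker inhibition and lower numbers for stronger inhibition. Compound 1 `N/C(=N\NC(=S)N1CCOCC1)c1ccccn1` gave 4700 nM. Compound 2 `N/C(=N\NC(=S)N1CCCCC1)c1ccccn1` differs by piperidin-1-yl in place of morpholin-4-yl on a thiocarbonyl carbon and gave 8500 nM, so that the step of a 1.8-fold higher number from compound 1 to compound 2 (0.26 log units; within the scatter) was small. Compound 3 `Cc1cccc(/C(N)=N/NC(=S)N2CCOCC2)n1` carries a different core, differing from compound 1 by methyl in place of hydrogen on an aromatic carbon; in this assay compound 3 gave 21500 nM, and the step of a 4.6-fold higher number from compound 1 to compound 3 (0.66 log units; beyond the scatter) was the larger of the two. Compound 3 thus gave the highest of the three numbers.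

Compound 4 `Cc1cccc(/C(N)=N/NC(=S)N2CCCCC2)n1` has not yet been measured. For the measured compounds named here, it differs from compound 3 by piperidin-1-yl in place of morpholin-4-yl on a thiocarbonyl carbon, which is the same change as the one from compound 1 to compound 2, made at the same place on the other core. Going by the values given here, only that one earlier instance is available to judge it. For compound 4 in this assay the step is expected to be a 1.8-fold higher number from compound 3 to compound 4 (0.25 log units; within the scatter). This expectation rests on the earlier step of a 1.8-fold higher number from compound 1 to compound 2 (0.26 log units; within the scatter), which lay within the scatter. Compound 4 is therefore estimated to give 38000 nM, with a range from 16000 nM to 90000 nM.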

Compound 4, half-maximal inhibitory concentration: 74000 nM
The estimate for compound 4 lay 1.9-fold (0.29 log units) below the measured number, and the stated range covers the measured number.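

On the methylated core, piperidin-1-yl in place of morpholin-4-yl gave a 3.4-fold higher number from compound 3 to compound 4 (0.54 log units; beyond the scatter) in this assay, and its two instances do not differ beyond what repeated measurement allows: the same change on two cores in this assay, a 1.8-fold higher number (0.26 log units; within the scatter) from compound 1 to compound 2 and a 3.4-fold higher number (0.54 log units; beyond the scatter) from compound 3 to compound 4, 1.9-fold (0.28 log units) apart, within the scatter of two such steps. Methyl in place of hydrogen on an aromatic carbon, read on the piperidin-1-yl pair, gave an 8.7-fold higher number from compound 2 to compound 4 (0.94 log units; beyond the scatter), and this change also carried over: the same change on two cores in this assay, a 4.6-fold higher number (0.66 log units; beyond the scatter) from compound 1 to compound 3 and an 8.7-fold higher number (0.94 log units; beyond the scatter) from compound 2 to compound 4, 1.9-fold (0.28 log units) apart, within the scatter of two such steps. Each change thus kept its direction on the second core and its size within the scatter, but both comparisons rest on the same four compounds and count as one observation, which does not show that the changes would carry over to other cores or explain why the numbers rise.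

The compounds shown leave open whether an open-chain amine such as diethylamino on the thiocarbonyl carbon would follow the same course. They also leave open whether ethyl or a longer chain on the aromatic carbon would do so.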